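A few compounds are considered here, and "the series" means these few. Any claim that something is new, unique, unknown or untested is made for them only; others in the source may bear on it.

Of the compounds shown here, three have so far been tested in a functional assay on HepG2 cells (Homo sapiens) for antiproliferative activity, read by sulforhodamine B assay, with a stated time of 48 h; a lower number here means a stronger inhibitor, a higher number a weaker inhibitor. Compound 1 `COc1cccc(C2=NNC(c3ccc(Cl)cc3)C2O)c1` gives 35.3 nM, and compound 2 `COc1cccc(C2=NNC(c3ccc(Br)cc3)C2O)c1` gives 43 nM. The only difference between them is bromo in place of chloro on an aromatic carbon, which produced a 1.2-fold higher number from compound 1 to compound 2 (0.09 log units; within the scatter). Compound 3 `COc1ccc(C(=O)C2OC2c2ccc(Cl)cc2)cc1` is built on a different core, and the difference between the two cores is not broken down here. In this assay compound 3 gives 15 nM, the lowest of the three numbers, a gap beyond the scatter from both compound 1 and compound 2.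

Compound 4 `COc1ccc(C(=O)C2OC2c2ccc(Br)cc2)cc1` has not yet been measured. Among the measured compounds shown here, it differs from compound 3 by bromo in place of chloro on an aromatic carbon, the same change as the one between compound 1 and compound 2, at a place described in the same words. That earlier change gave only a 1.2-fold higher number from compound 1 to compound 2 (0.09 log units; within the scatter). On that basis the expected step in this assay is a 1.2-fold higher number from compound 3 to compound 4 (0.08 log units; within the scatter), small enough to stay within the usual scatter. Compound 4 is therefore estimated at 18 nM, most likely falling between 9 nM and 36 nM.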

Compound 4, half-maximal inhibitory concentration: 30 nM
The estimate for compound 4 lay 1.7-fold (0.22 log units) below the measured number; measured number inside the range.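

In this assay, bromo in place of chloro on the core of compound 3 gave a 2.0-fold higher number from compound 3 to compound 4 (0.30 log units; within the scatter), so the swap stays inside the usual noise of the measurement here, as it did on the core of compound 1. Set side by side, the two steps cannot be told apart: the same change on two cores in this assay, a 1.2-fold higher number (0.09 log units; within the scatter) from compound 1 to compound 2 and a 2.0-fold higher number (0.30 log units; within the scatter) from compound 3 to compound 4, 1.6-fold (0.22 log units) apart, within the scatter of two such steps. This shows that, for these two pairs, the change carried from one core to the other without a detectable difference; it does not show that the two cores respond identically, as a real gap smaller than the scatter would go unseen, and two pairs say nothing about any further core or any other change.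

The compounds shown carry only chloro or bromo at this place, so what a fluoro, a methyl or an amine there would do on either core remains open. Also open, going by these compounds, is which part of the cores separates compound 3 from compound 1.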